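Trimming the hydroxycarbamoyl chain by one step

A few compounds are considered here, and "the series" means these few. Any claim that something is new, unique, unknown or untested is made for them only; others in the source may bear on it.

Of the compounds shown here, two have so far been measured in a functional assay on Hep 3B2 cells (Homo sapiens) for antiproliferative activity, read by sulforhodamine B assay, with a stated time of 48 h; on this read-out higher numbers stand for weaker inhibition of growth and lower numbers for stronger inhibition of growth. There, compound 1 (`CC(C)CCc1c(OCCCCCC(=O)NO)ccc2ccc(=O)oc12`) gives 800 nM and compound 2 (`CC(C)CCc1c(OCCCCCCCC(=O)NO)ccc(CCC(=O)NO)c1O`) gives 1270 nM. These two values lie within the usual scatter of each other, so compound 1 stands level with compound 2 and neither can be ranked above the other.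

The next candidate, compound 3 (`CC(C)CCc1c(OCCCCC(=O)NO)ccc2ccc(=O)oc12`), keeps the core of compound 1 and alters only its chain: hydroxycarbamoyl in place of (hydroxycarbamoyl)methyl on a saturated chain carbon, four bonds along the chain from an oxygen on an aromatic ring. Read one bond further out, this is 4-(hydroxycarbamoyl)butyl to 3-(hydroxycarbamoyl)propyl. Within the data shown here, no measured pair here isolates such a change, so the data give no direct guide to its size or direction, and any forecast is tentative. Taking compound 1 at 800 nM as the anchor, a small loss seems likelier than a gain. The expected move is a 1.9-fold higher number from compound 1 to compound 3 (0.27 log units; within the scatter), a step towards weaker inhibition of growth of about the size of the scatter. For compound 3 the estimated value is 1500 nM, with an expected range from 600 nM to 5000 nM.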

Compound 3, concentration for 50% growth inhibition: 1310 nM
Estimate against measurement, compound 3: 1.1-fold (0.06 log units) above; the measured number falls inside the stated range.
By their numbers in this assay, from the lowest: compounds 1, 2 and 3 (each within the scatter of the next).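

Among these compounds, replacing (hydroxycarbamoyl)methyl with hydroxycarbamoyl on a saturated chain carbon, four bonds along the chain from an oxygen on an aromatic ring, gives the first pair here that differs in one place, and in this assay this change reads as a 1.6-fold higher number from compound 1 to compound 3 (0.21 log units; within the scatter) and no more. At this position, on the shared core, the 4-(hydroxycarbamoyl)butyl chain and the 3-(hydroxycarbamoyl)propyl chain therefore cannot be told apart on this read-out, so the one chain carbon that separates them makes no difference that rises above the scatter. Among the compounds shown here, nothing measured so far speaks to why the two chains read alike.

From the compounds shown here alone, whether a still shorter chain such as 2-(hydroxycarbamoyl)ethyl, or a chain longer than that of compound 1, would carry the number beyond the scatter remains open, as a single step sets no trend in either direction. Going by these compounds, it is equally open how much depends on the end group itself, which a carboxylic acid or a primary amide on the same chain and the same core would test.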